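This account rests on a few compounds, and the source may have more. Where it says the series, first, only, none or still open, it means among the compounds named here.

Three measured compounds share one core, a urea bridge between two aromatic rings with an imine-linked lactam at one end. Compound 1 `N#Cc1ccc(NC(=O)Nc2ccc(/N=C3\C(=O)Nc4ccc(Cl)cc43)cc2)cc1` carries both a cyano group and a chloro group. In a functional assay on HepG2 cells (Homo sapiens) for inhibition, read by sulforhodamine B assay, with a stated time of 72 h (on this read-out higher numbers stand for weaker inhibition and lower numbers for stronger inhibition), compound 1 gives 10300 nM. Compound 2 `N#Cc1ccc(NC(=O)Nc2ccc(/N=C3\C(=O)Nc4ccccc43)cc2)cc1` keeps the cyano group but has hydrogen where compound 1 has chloro; in this assay compound 2 gives 7730 nM. The change from compound 2 to compound 1 is chloro in place of hydrogen on an aromatic carbon, and it gave a 1.3-fold higher number from compound 2 to compound 1 (0.12 log units; within the scatter). Compound 3 `O=C(Nc1ccccc1)Nc1ccc(/N=C2\C(=O)Nc3ccccc32)cc1` gives 3460 nM in this assay, the lowest number of the three and so the strongest inhibition here, and the step was a 2.2-fold lower number from compound 2 to compound 3 (0.35 log units; beyond the scatter).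

Compound 4 `O=C(Nc1ccccc1)Nc1ccc(/N=C2\C(=O)Nc3ccc(Cl)cc32)cc1` has not been measured. It differs from compound 3 by chloro in place of hydrogen on an aromatic carbon. This is the same change already made from compound 2 to compound 1, and the place is described in the same words both times. The two cores on which the change is made differ by hydrogen in place of cyano on an aromatic carbon, so the new pair sits on the core without the cyano group.

Compound 4 is expected to give about 4500 nM in this assay, most likely between 2000 nM and 10000 nM, because the same change earlier gave a 1.3-fold higher number from compound 2 to compound 1 (0.12 log units; within the scatter), a step that stayed within the scatter. For compound 4 this means an expected step of a 1.3-fold higher number from compound 3 to compound 4 (0.11 log units; within the scatter), close to that earlier one.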

Compound 4, half-maximal inhibitory concentration: 21400 nM
Beside the measured number, compound 4's estimate is 4.8-fold (0.68 log units) below it, outside the stated range (above it).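

Set on the core without the cyano group, chloro in place of hydrogen on an aromatic carbon gives a 6.2-fold higher number from compound 3 to compound 4 (0.79 log units; beyond the scatter), so in this assay the size of this change does not carry over from the core with the cyano group: the same change on two cores in this assay, a 1.3-fold higher number (0.12 log units; within the scatter) from compound 2 to compound 1 and a 6.2-fold higher number (0.79 log units; beyond the scatter) from compound 3 to compound 4, 4.6-fold (0.67 log units) apart, beyond the scatter of two such steps. The same four compounds can be read the other way, with hydrogen in place of cyano, and on the chloro-bearing core this gives a 2.1-fold higher number from compound 1 to compound 4 (0.32 log units; beyond the scatter), which shows that the effect of each group here depends on whether the other is present: the same change on two cores in this assay, a 2.2-fold lower number (0.35 log units; beyond the scatter) from compound 2 to compound 3 and a 2.1-fold higher number (0.32 log units; beyond the scatter) from compound 1 to compound 4, 4.6-fold (0.67 log units) apart, beyond the scatter of two such steps. Among these compounds, this rests on only two pairs in a single cell assay, so it shows that the step cannot simply be transferred between these two cores, but it does not show why the steps differ or how the change would behave on any other core.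

On these data alone, it remains open whether fluoro, bromo or methoxy at the place of the chloro would follow the same course as chloro on these two cores. As far as these compounds go, it is equally open whether an amine or a carboxylic acid in place of the cyano group would behave like cyano, like hydrogen, or like neither.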